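Methyl for Trifluoromethyl: Estimating Compound 3

A few compounds are considered here, and "the series" means these few. Any claim that something is new, unique, unknown or untested is made for them only; others in the source may bear on it.

For the measured compounds named here, compound 2 `CN(C(=O)NC(=O)c1c(F)cccc1F)c1nc(C(F)(F)F)c(C(=O)N/N=C/c2cccc(C(F)(F)F)c2)s1` gives 21.6 ug/mL in a functional assay on HeLa cells (Homo sapiens) for inhibition, read by MTT assay, with a stated time of 72 h (on this read-out lower numbers stand for stronger inhibition and higher numbers for weaker inhibition), the highest of the two numbers measured so far. Its nearest neighbour, compound 1 `CN(C(=O)NC(=O)c1ccc(Cl)cc1Cl)c1nc(C(F)(F)F)c(C(=O)N/N=C/c2cccc(C(F)(F)F)c2)s1`, gives 9.6 ug/mL. The step between them is a 2.3-fold higher number from compound 1 to compound 2 (0.35 log units; beyond the scatter). Compound 1 and compound 2 differ only in the aryl group on the carbonyl carbon. Compound 3 `Cc1nc(N(C)C(=O)NC(=O)c2c(F)cccc2F)sc1C(=O)N/N=C/c1cccc(C(F)(F)F)c1` departs from compound 2 at a different place: methyl in place of trifluoromethyl on an aromatic carbon. Going by the values given here, the only measured step, a 2.3-fold higher number from compound 1 to compound 2 (0.35 log units; beyond the scatter), concerns the aryl group on the carbonyl carbon and not the five-membered aromatic ring, so no measured step bears directly on the exchange of trifluoromethyl for methyl. Among the compounds with values here, with no precedent in this small set, no step beyond the scatter is expected in this assay for compound 3, in either direction. The estimate for compound 3 is therefore 21.6 ug/mL, with a range from 8 ug/mL to 55 ug/mL. The step this estimate implies, no change at the digits printed from compound 2 to compound 3 (within the scatter), is expected to be small.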

Compound 3, half-maximal inhibitory concentration: 26.8 ug/mL
Compound 3: middle estimate off by 1.2-fold (0.09 log units), on the low side; the range from low to high includes it.
By their numbers in this assay, from the lowest: compound 1; then compounds 2 and 3 (each within the scatter of the next).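

In this assay, methyl in place of trifluoromethyl on the aromatic carbon next to the ring nitrogen gives a 1.2-fold higher number from compound 2 to compound 3 (0.09 log units; within the scatter), a step that stays small even though the whole trifluoromethyl group is exchanged. For the compounds shown here, this is the first reading at this position, since the earlier step concerned only the aryl group on the carbonyl carbon, and it shows that, with the 2,6-difluorophenyl group in place, these two groups cannot be told apart on this read-out. No measurement is available that would account for this result.

As far as these compounds go, whether the same exchange would stay as small with the 2,4-dichlorophenyl group of compound 1 remains open. The compounds shown also leave open how this position would respond to a quite different group, such as an amine, a carboxylic acid or a longer chain.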